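Adding an imidazolylbutyl chain to compound 3

The compounds below may be only part of what the source reports. "The series", "measured", "known", "first", "only" and "open" are said of these compounds alone.

- compound 1 `Cn1cc(C2=C(c3nn(CCCn4cccc4)c4ncccc34)C(=O)NC2=O)c2ccccc21` gives > 100000 nM as a limit
- compound 2 `CN1CCN(CCCn2nc(C3=C(c4cn(C)c5ccccc45)C(=O)NC3=O)c3cccnc32)CC1` gives > 100000 nM as a limit
- compound 3 `Cn1cc(C2=C(c3n[nH]c4ncccc34)C(=O)NC2=O)c2ccccc21` gives 62000 nM as a number

For the measured compounds named here, in a functional assay on KB cells (Homo sapiens) for antiproliferative activity, read by MTT assay, with a stated time of 48 h (a lower number here means a stronger inhibitor, a higher number a weaker inhibitor), compound 3 gives 62000 nM as the only true number of the three. Compound 4 `Cn1cc(C2=C(c3nn(CCCCn4ccnc4)c4ncccc34)C(=O)NC2=O)c2ccccc21` differs from compound 3 by 4-(1H-imidazol-1-yl)butyl in place of hydrogen on an aromatic nitrogen with 4-(1H-imidazol-1-yl)butyl in place of hydrogen on an aromatic nitrogen. Going by the values given here, two measured steps bear on this, each taking a chain away from that nitrogen: an at least 1.6-fold lower number from compound 1 to compound 3 (0.20 log units; that floor lies within the scatter) and also an at least 1.6-fold lower number from compound 2 to compound 3 (0.20 log units; that floor lies within the scatter) with only a floor for their size. Adding a chain is therefore expected to run the other way in this assay toward a higher number. The expected step is a 1.5-fold higher number from compound 3 to compound 4 (0.16 log units; within the scatter) and the assay may report only a limit. For compound 4 the estimate is 90000 nM with an expected range of 35000 nM to 150000 nM overall.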

Compound 4, half-maximal inhibitory concentration: > 100000 nM
Compound 4: no number, only a limit; the forecaster's own chance of this, stated with the estimate: 60%; at least 1.1-fold (0.04 log units) between middle value and limit.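

In this assay, placing 4-(1H-imidazol-1-yl)butyl on the aromatic nitrogen gives an at least 1.6-fold higher number from compound 3 to compound 4 (0.20 log units; that floor lies within the scatter), so this floor, like those of the two earlier chains, does not separate the change from scatter. The steps among compound 1, compound 2 and compound 4 cannot be read. A third chain, with a different end group, thus joins the other two at one limit: the limit of > 100000 nM in this assay, at which 3 of the 4 values shown sit.

As far as these compounds go, how far past that limit each chain lies stays open, so the chains cannot be ranked. From the compounds shown here alone, whether a small methyl group or a chain ending in a carboxylic acid would give a readable number also stays open.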